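The source may report more compounds than this note shows. Statements on the series, on what has been measured and on what is new or still open speak of the compounds shown alone.

This series shares one core, seen in compound 1 `O=c1[nH]cc(S(=O)(=O)Nc2cccc(-c3cn(-c4ccccc4)nn3)c2)c(=O)[nH]1`, where a phenyl sits on an aromatic nitrogen of the shared core. In an ADME assay on GES1 cells (Homo sapiens) for cytotoxicity, read by MTT assay, with a stated time of 24 h (a higher number here means that more compound is tolerated, a lower number that less compound is tolerated), compound 1 gives 22500 nM. Compound 2 `Cc1ccccc1-n1cc(-c2cccc(NS(=O)(=O)c3c[nH]c(=O)[nH]c3=O)c2)nn1` carries a methyl in place of a hydrogen on an aromatic carbon, and in this assay compound 2 gives 21500 nM; the step of a 1.0-fold lower number from compound 1 to compound 2 (0.02 log units; within the scatter) lies within the scatter. Among the compounds with values here, compound 3 `O=c1[nH]cc(S(=O)(=O)Nc2cccc(-c3cn(-c4ccccc4F)nn3)c2)c(=O)[nH]1` bears a 2-fluorophenyl on the aromatic nitrogen, and in this assay compound 3 was recorded as "not toxic" (no number reported), so no single number stands for it and no step of a stated size can be drawn from it. Compound 4 `O=c1[nH]cc(S(=O)(=O)Nc2cccc(-c3cn(-c4ccc(F)cc4)nn3)c2)c(=O)[nH]1` differs from compound 3 by 4-fluorophenyl in place of 2-fluorophenyl on an aromatic nitrogen. Within the data shown here, the only measured step, from compound 1 to compound 2, concerns a different change and was within the scatter, so it offers little guidance; what remains is that the two numbered compounds lie close together and compound 3 was tolerated. On that footing compound 4 is expected to be tolerated at a similar or somewhat higher level, with an estimated value of 30000 nM, within a range from 12000 nM to 100000 nM, and a real chance that again no number is reported.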

Compound 4, half-maximal cytotoxic concentration: "not toxic" (no number reported)
Compound 4 has no reported number here; no gap can be computed for the estimate.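

In this assay, within the data shown here, compound 3 and compound 4 were both recorded as not toxic without a number, so no step between them can be read. As far as these compounds go, whether 4-fluorophenyl and 2-fluorophenyl differ in how much compound is tolerated stays open. No measurement shown here bears on this result.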